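Benzyl Swap on the Smaller Core: Compound 3 to Compound 4

The compounds below may be only part of what the source reports. "The series", "measured", "known", "first", "only" and "open" are said of these compounds alone.

The study followed cytotoxicity in a functional assay on MDA-MB-231 cells (Homo sapiens) for cytotoxicity, read by MTT assay, with a stated time of 72 h (a higher number here means a weaker inhibitor, a lower number a stronger inhibitor), across three measured compounds and one still to be tested. Compound 1, `COc1ccc(Cn2nc(-c3ccccc3)c3cc(C(=N)Nc4ccccc4)nc(NC4CCCCC4)c32)cc1`, gives 3400 nM. Compound 2, `COc1ccc(Cn2cc3cc(C(=N)Nc4ccccc4)ncc3n2)cc1`, gives 1520 nM. Compound 3, `CN1CCN(c2ccc(NC(=N)c3cc4cn(C)nc4cn3)cc2)CC1`, gives 20500 nM, the highest number of the three, separated from compound 1 and from compound 2 by gaps that lie beyond the usual scatter.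

Compound 4, `COc1ccc(Cn2cc3cc(C(=N)Nc4ccc(N5CCN(C)CC5)cc4)ncc3n2)cc1`, differs from compound 3 in one place: 4-methoxyphenyl in place of hydrogen on a saturated chain carbon bound to an aromatic nitrogen. For the measured compounds named here, no measured pair shows this change on its own, so its effect can only be guessed from the neighbours. The same 4-methoxybenzyl substituent is present in compound 2, which gives 1520 nM, while compound 3 with its methyl gives 20500 nM; the two also differ elsewhere, so this is a loose guide.

The step of a 4.6-fold lower number from compound 3 to compound 4 (0.66 log units; beyond the scatter) is therefore expected to run toward a lower number and to exceed the scatter. Compound 4 is estimated at 4500 nM, with a range from 1300 nM to 15000 nM.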

Compound 4, half-maximal inhibitory concentration: 8000 nM
Beside the measured number, compound 4's estimate is 1.8-fold (0.25 log units) below it; the range from low to high includes it.
By their numbers in this assay, from the lowest: compound 2; then compound 1; then compound 4; then compound 3.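

In this assay, methyl to 4-methoxybenzyl can now be read on its own: with the 4-methylpiperazin-1-yl group held in place, it gives a 2.6-fold lower number from compound 3 to compound 4 (0.41 log units; beyond the scatter) and so shows that this position responds to the change. For the compounds shown here, with 4-methoxybenzyl held in place, 4-methylpiperazin-1-yl in place of hydrogen on an aromatic carbon gives a 5.3-fold higher number from compound 2 to compound 4 (0.72 log units; beyond the scatter) and so moves the number the opposite way, an effect that the earlier compounds could not separate. Nothing measured here explains either step.

From the compounds shown here alone, whether plain benzyl or a longer chain such as 2-phenylethyl would give a similar step at this position remains open. Also open, going by these compounds, are whether morpholine could take the place of 4-methylpiperazin-1-yl and whether either step would carry over to the core of compound 1.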